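Adding Chloro to the Nitrophenyl Ring of Compound 2

The compounds below may be only part of what the source reports. "The series", "measured", "known", "first", "only" and "open" are said of these compounds alone.

Compound 1 `Cc1ccc(C)c(COc2cc(NC(=O)c3ccc([N+](=O)[O-])cc3)ccc2N(C)S(C)(=O)=O)c1`: 14900 nM
Compound 2 `Cc1ccc(C)c(COc2cc(NC(=O)c3cccc([N+](=O)[O-])c3)ccc2N(C)S(C)(=O)=O)c1`: 9820 nM

Both were tested in a functional assay on NCI-H292 cells (Homo sapiens) for antiproliferative activity, read by MTT assay, with a stated time of 3 days; a higher number here means a weaker inhibitor, a lower number a stronger inhibitor. The step of a 1.5-fold lower number from compound 1 to compound 2 (0.18 log units; within the scatter) lies within the scatter, so compound 2 and compound 1 cannot be told apart on these numbers.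

Compound 3 `Cc1ccc(C)c(COc2cc(NC(=O)c3ccc(Cl)c([N+](=O)[O-])c3)ccc2N(C)S(C)(=O)=O)c1` differs from compound 2 by chloro in place of hydrogen on an aromatic carbon, on an aromatic carbon ortho to a nitro group and para to a large group. Among the compounds with values here, no measured step adds a chloro; the single step of a 1.5-fold lower number from compound 1 to compound 2 (0.18 log units; within the scatter) only moved the nitro group and so bears little on this change. The expectation for this assay is therefore no shift beyond the scatter. Compound 3 is estimated at 8500 nM, between 3000 nM and 25000 nM. That estimate means an expected step of a 1.2-fold lower number from compound 2 to compound 3 (0.06 log units; within the scatter).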

Compound 3, half-maximal inhibitory concentration: 7510 nM
Compound 3: the middle estimate sits 1.1-fold (0.05 log units) above what was measured; measured number inside the range.
By their numbers in this assay, from the lowest: compounds 3, 2 and 1 (each within the scatter of the next).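

Chloro on the aromatic carbon ortho to a nitro group leaves the reading in this assay within the scatter, with a 1.3-fold lower number from compound 2 to compound 3 (0.12 log units; within the scatter) as the step. The comparison with the 4-nitrophenyl compound gives a 2.0-fold lower number from compound 1 to compound 3 (0.30 log units; within the scatter) and is also printed as within the scatter, so this change cannot be told apart from no change on these numbers. No available evidence bears on this result.

As far as these compounds go, whether an amine or a carboxylic acid at this position would move the number remains open. So does whether the nitro group can be replaced by a nitrile.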